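The source may hold more compounds than are shown below. What is called first, only, known or untested is meant among the compounds shown, and "the series" means these compounds.

Compound 1 `CN(Cc1cccc(C(=O)O)c1)c1ccc(OCc2c(-c3c(Cl)cccc3Cl)noc2C2CC2)nc1C(F)(F)F`: in a functional assay on HEK293 cells for agonist activity at Bile acid receptor (Homo sapiens) (on this read-out higher numbers stand for an effect only at larger amounts of compound and lower numbers for an effect already at smaller amounts), compound 1 gives 9 nM.
Compound 2 `CC(Nc1ccc(C(=O)O)cc1)c1ccc(OCc2c(-c3c(Cl)cccc3Cl)noc2C2CC2)nc1C(F)(F)F`: in this assay compound 2 gives 333 nM.

Compound 2 has the highest of the two numbers; its nearest neighbour is compound 1, reached by a 37-fold higher number from compound 1 to compound 2 (1.57 log units; beyond the scatter). Compound 3 `CC(c1ccc(OCc2c(-c3c(Cl)cccc3Cl)noc2C2CC2)nc1C(F)(F)F)N(C)c1ccc(C(=O)O)cc1` carries methyl in place of hydrogen on a nitrogen on an aromatic ring. Among the measured compounds shown here, only one measured step bears on this, the one from compound 1 to compound 2, and it changes more than the methyl on the nitrogen alone, so it informs the direction only loosely; compound 1, with the methylated nitrogen, gives the lower number. The step to compound 3 is therefore expected to be a 3.0-fold lower number from compound 2 to compound 3 (0.48 log units; beyond the scatter). Compound 3 is estimated at 110 nM, within 25 nM to 450 nM.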

Compound 3, half-maximal effective concentration: 208 nM
The estimate for compound 3 lay 1.9-fold (0.28 log units) below the measured number, within the range that was stated.
By their numbers in this assay, from the lowest: compound 1; then compounds 3 and 2 (each within the scatter of the next).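

In this assay, methyl in place of hydrogen on this nitrogen gives a 1.6-fold lower number from compound 2 to compound 3 (0.20 log units; within the scatter), so the position accepts this one added carbon with no change that can be told from the scatter. The methyl alone therefore does not account for a 37-fold higher number from compound 1 to compound 2 (1.57 log units; beyond the scatter), which must lie in the other differences between those two compounds. Nothing measured here bears on why the methyl leaves the number in place.

On these data alone, whether an ethyl group, a longer chain or an acetyl group on this nitrogen would be accepted in the same way remains open.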